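Swapping a Ring Chlorine for Fluorine in Compound 2

A few compounds are considered here, and "the series" means these few. Any claim that something is new, unique, unknown or untested is made for them only; others in the source may bear on it.

Compound 1, `CCS(=O)(=O)Nc1ccc(NC(=O)c2ccc(Cl)cc2)cc1Cl`: in an ADME assay on RAW264.7 cells (Mus musculus) for cytotoxicity, read by MTT assay, with a stated time of 48 h (a lower number here means a stronger inhibitor, a higher number a weaker inhibitor), compound 1 gives > 250000 nM, which is a limit of the assay.
Compound 2, `O=C(Nc1ccc(NS(=O)(=O)C(F)(F)F)c(Cl)c1)c1ccc(Cl)cc1`: in this assay compound 2 gives 47200 nM.
Compound 3, `N#Cc1ccc(C(=O)Nc2ccc(NS(=O)(=O)C(F)(F)F)c(Cl)c2)cc1`: in this assay compound 3 gives > 250000 nM, again a limit.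

Among the measured compounds shown here, compound 2 is the only one with a real number; the other two sit at the limit of > 250000 nM in this assay, at which 2 of the 3 values shown sit. The step of an at least 5.2-fold lower number from compound 1 to compound 2 (0.72 log units; beyond the scatter) and the step of an at least 5.2-fold higher number from compound 2 to compound 3 (0.72 log units; beyond the scatter) show that single changes move this number beyond the scatter. Compound 4, `O=C(Nc1ccc(NS(=O)(=O)C(F)(F)F)c(F)c1)c1ccc(Cl)cc1`, differs from compound 2 by fluoro in place of chloro on an aromatic carbon. For the measured compounds named here, no measured step swaps one halogen for another, so neither bears directly on it. For compound 4 a step of a 1.7-fold higher number from compound 2 to compound 4 (0.23 log units; within the scatter) is expected, a mild weakening at most. The estimate for compound 4 is 80000 nM, between 30000 nM and 250000 nM.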

Compound 4, half-maximal inhibitory concentration: 3270 nM
For compound 4 the middle estimate is 24-fold (1.39 log units) above the measured one; measured number outside the range, below it.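

At this position, ortho to a ((trifluoromethyl)sulfonyl)amino group, exchanging one halogen for another matters in this assay: fluoro in place of chloro gives a 14-fold lower number from compound 2 to compound 4 (1.16 log units; beyond the scatter). Among the compounds shown here, the earlier steps changed the group on the sulfonyl sulfur and the chloro that cyano replaced, so this is the first sign that this position also moves the number. It is also the one step here with real numbers at both ends, the others resting on a limit: the limit of > 250000 nM in this assay, at which 2 of the 4 values shown sit.

On these data alone, whether an amine or a methyl group at this position would give a lower or higher number stays open. So does whether the same halogen exchange would have a similar effect with the ethyl group of compound 1 or the cyano group of compound 3.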